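Swapping the Aryl Group on Compound 2 for a Catechol

The source may report more compounds than this note shows. Statements on the series, on what has been measured and on what is new or still open speak of the compounds shown alone.

Measured so far in a functional assay on MCF-A cells (Homo sapiens) for cytotoxicity (on this read-out lower numbers stand for stronger inhibition of growth and higher numbers for weaker inhibition of growth), the values are
Compound 1 `COc1ccc(C2=C(c3ccc(SC)cc3)CC3CCCN3C2=O)cc1O` with 5000 nM
Compound 2 `CSc1ccc(C2=C(c3ccc(F)c(C)c3)C(=O)N3CCCC3C2)cc1` with 500 nM

Of these two numbers, compound 2 holds the lower at 500 nM and serves as the starting point. The change to compound 3 `CSc1ccc(C2=C(c3ccc(O)c(O)c3)C(=O)N3CCCC3C2)cc1` is 3,4-dihydroxyphenyl in place of 4-fluoro-3-methylphenyl on a double-bonded ring carbon and it puts 3,4-dihydroxyphenyl in place of 4-fluoro-3-methylphenyl on a double-bonded ring carbon. Within the data shown here, only one measured step bears on this, a 10-fold lower number from compound 1 to compound 2 (1.00 log units; beyond the scatter) with 4-fluoro-3-methylphenyl in place of 3-hydroxy-4-methoxyphenyl on a double-bonded ring carbon. Here the change runs the other way, toward a hydroxy-bearing phenyl, so a rise of broadly similar size is expected. The expected move is a 6.0-fold higher number from compound 2 to compound 3 (0.78 log units; beyond the scatter) and it rests on that single step. For compound 3 the estimated value is 3000 nM with 800 nM to 10000 nM as the expected range.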

Compound 3, concentration for 50% growth inhibition: 80000 nM
Estimate against measurement, compound 3: 27-fold (1.43 log units) below; the whole stated range lies below it.
By their numbers in this assay, from the lowest: compound 2; then compound 1; then compound 3.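

In this assay the 3,4-dihydroxyphenyl group at this double-bonded ring carbon gives a 160-fold higher number from compound 2 to compound 3 (2.20 log units; beyond the scatter) and so reaches further than the earlier step of a 10-fold lower number from compound 1 to compound 2 (1.00 log units; beyond the scatter) at the same position. The step of a 16-fold higher number from compound 1 to compound 3 (1.20 log units; beyond the scatter) adds something the first two compounds could not show: with the rest of the structure unchanged, hydrogen in place of methyl on a single aromatic oxygen moves the number by a large amount, so this position responds strongly even to that small edit. No measurement offered here accounts for these shifts.

Still open, from the compounds shown here alone, is whether 3,4-dimethoxyphenyl, with methyl on both oxygens, would bring the number closer to that of compound 2. Also open, going by these compounds, is how an aminophenyl or carboxyphenyl group would behave at this ring carbon.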